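Side-chain change on the shared core: compound 3 to compound 4

A few compounds are considered here, and "the series" means these few. Any claim that something is new, unique, unknown or untested is made for them only; others in the source may bear on it.

The series is followed in an ADME assay on MRC5 cells (Homo sapiens) for inhibition, with a stated time of 72 h; on this read-out lower numbers stand for an effect already at smaller amounts and higher numbers for an effect only at larger amounts of compound. Compound 1, `CO[C@H]1CC[C@H](NC(=O)c2n[nH]cc2NC(=O)c2ccc(-c3ccccc3)o2)CC1`, gives 100 nM in this assay. Compound 2, `CO[C@H]1CC[C@H](NC(=O)c2n[nH]cc2NC(=O)c2cc3ccccn3n2)CC1`, gives 1000 nM in this assay. Compound 3, `COCCNC(=O)c1n[nH]cc1NC(=O)c1c(OC)cccc1OC`, returns only a limit in this assay, > 50000 nM. On the numbers shown, compound 3 thus stands at the limit of > 50000 nM in this assay, at which 1 of the 3 values shown sits, the only one of the three that yields no number. For the measured compounds named here, no step between measured compounds is available, so each value can only be read on its own.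

Compound 4, `CCCCCNC(=O)c1n[nH]cc1NC(=O)c1c(OC)cccc1OC`, is the unmeasured partner of compound 3. The change is propyl in place of methoxy on a saturated chain carbon, two bonds along the chain from an amide-type nitrogen. The two compounds differ nowhere else. Compound 3 gives no number in this assay, so the step to compound 4 has no measured starting point; a result that stays near the limit would count as no change beyond the scatter, and nothing in this set ties such a chain change to a shift of known size. Compound 4 is therefore expected to sit at or near the limit as well. The expected step is a number no higher from compound 3 to compound 4 (the limit leaves the size open) in this assay. The estimate for compound 4 in this assay is 50000 nM, expected to fall between 20000 nM and 150000 nM, with a high chance that only a limit is reported again.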

Compound 4, half-maximal effective concentration: > 50000 nM
Compound 4 ended at the assay's limit; the forecaster's own chance of this, stated with the estimate: 85%; the middle value lies on the limit itself.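

Compound 3 and compound 4 both end as limits in this assay, so no step can be read for propyl in place of methoxy on the chain. The compounds shown leave open how far either compound lies past the limit, and whether this chain change has any effect on the read-out at all.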